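Amino for fluoro on the thiazole of a cyanophenyl alkyne

A few compounds are considered here, and "the series" means these few. Any claim that something is new, unique, unknown or untested is made for them only; others in the source may bear on it.

Measured so far:
compound 1 `N#Cc1cccc(C#Cc2csc(F)n2)c1`, 1.6 nM
compound 2 `Fc1nc(C#Cc2ccccc2)cs1`, 122 nM

Compound 1 gives the lowest of the two numbers in an assay on brain for displacement of a labelled ligand from metabotropic glutamate receptor 5 (Rattus norvegicus) (a lower number here means a stronger inhibitor, a higher number a weaker inhibitor), and its nearest neighbour is compound 2 with a 76-fold higher number from compound 1 to compound 2 (1.88 log units; beyond the scatter), a change made by hydrogen in place of cyano on an aromatic carbon of the phenyl ring. Among the measured compounds shown here, that is the only measured step here, and it touches the phenyl end, not the five-membered ring.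

Compound 3 `N#Cc1cccc(C#Cc2csc(N)n2)c1` is not yet measured. It differs from compound 1 by amino in place of fluoro on an aromatic carbon. For the measured compounds named here, no measured pair shows what this exchange does in this assay, so the step from compound 1 to compound 2 gives no direct guide; it shows only that the cyano end matters greatly while the other end is untested.

With nothing to anchor the change on the five-membered ring, a modest step is expected, a 3.8-fold higher number from compound 1 to compound 3 (0.57 log units; beyond the scatter), leaning toward a higher number. Compound 3 is therefore estimated at 6 nM, with a range from 1.2 nM to 40 nM.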

Compound 3, inhibition constant: 0.9 nM
Compound 3: the middle estimate sits 6.7-fold (0.82 log units) above what was measured; the measured number lies below the stated range.
By their numbers in this assay, from the lowest: compounds 3 and 1 (each within the scatter of the next); then compound 2.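

In this assay, among the compounds shown here, the exchange on the five-membered aromatic ring gives a 1.8-fold lower number from compound 1 to compound 3 (0.25 log units; within the scatter) and so compound 1 and compound 3 cannot be told apart, which is the first measured reading at this end of the molecule. Fluoro and amino, each a single heavy atom on the carbon next to the ring nitrogen and the ring sulfur, differ in that amino counts as a hydrogen-bond donor and acceptor while fluoro counts as neither, yet this difference produces no step beyond the scatter here, in contrast to the exchange at the other end, where hydrogen in place of cyano gives a 76-fold higher number from compound 1 to compound 2 (1.88 log units; beyond the scatter) as a large step. No independent measurement is available to explain why these two groups give numbers within the scatter of each other.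

The compounds shown leave open whether a larger group on this carbon, such as dimethylamino, acetamido or methyl, would also stay within the scatter of compound 1. They also leave open whether amino in place of fluoro would give a similar step on compound 2, which has no cyano group on its phenyl ring.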